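Compound 2 to compound 3: exchanging one methylimidazolyl group for another

A few compounds are considered here, and "the series" means these few. Any claim that something is new, unique, unknown or untested is made for them only; others in the source may bear on it.

In an ADME assay on a cell-free system (plasma, Homo sapiens) for protein binding (a lower number here means a smaller unbound share, a higher number a larger unbound share of the compound), compound 1 `Cc1cc(C)c(-c2ncc[nH]2)cc1NC(=O)c1ccc(OCc2ccccn2)cc1` gives 0.067 and compound 2 `Cc1cc(C)c(-c2cn(C)cn2)cc1NC(=O)c1ccc(OCc2ccccn2)cc1` gives 0.055 (the two values lie within the scatter of each other). Compound 3 `Cc1ncc(-c2cc(NC(=O)c3ccc(OCc4ccccn4)cc3)c(C)cc2C)[nH]1` has the same atoms as compound 2, with 2-methyl-1H-imidazol-5-yl in place of 1-methyl-1H-imidazol-4-yl on an aromatic carbon. Among the compounds with values here, the one measured step that bears on this change also exchanges imidazolyl groups at that place and stays within the scatter (a 1.2-fold lower number from compound 1 to compound 2 (0.09 log units; within the scatter)). No step beyond the scatter is therefore expected, and the estimated step is a 1.1-fold higher number from compound 2 to compound 3 (0.04 log units; within the scatter) in this assay for this pair. Compound 3 is estimated at 0.06 (expected range 0.035 to 0.1).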

Compound 3, unbound fraction: 0.095
The estimate for compound 3 lay 1.6-fold (0.20 log units) below the measured number; low and high end bracket the measured number.
By their numbers in this assay, from the lowest: compounds 2, 1 and 3 (each within the scatter of the next).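

In this assay the step of a 1.7-fold higher number from compound 2 to compound 3 (0.24 log units; within the scatter) and the step of a 1.4-fold higher number from compound 1 to compound 3 (0.15 log units; within the scatter) show that this place on the shared core tolerates a third imidazolyl group without leaving the scatter. Exchanging 1-methyl-1H-imidazol-4-yl, which has no hydrogen-bond donor, for 2-methyl-1H-imidazol-5-yl, which has one, therefore gives no readable change in the unbound fraction. Nothing available here explains these numbers.

Still open, from the compounds shown here alone, is whether an amine or a carboxylic acid on the imidazolyl group, or a longer chain in place of its methyl group, would move the unbound fraction beyond the scatter.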